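Amino to Methoxy: A Small Change, Small Expected Shift

The source may hold more compounds than are shown below. What is called first, only, known or untested is meant among the compounds shown, and "the series" means these compounds.

Two compounds have been measured in a functional assay on BT-549 cells (Homo sapiens) for cytotoxicity, read by sulforhodamine B assay, with a stated time of 48 h, tested at 0.01 uM; a lower number here means a stronger effect, a higher number a weaker effect of the compound at the concentration tested:

Compound 1 `COc1cc(-c2cc(/C=C/C(=O)c3ccc(N)cc3)[nH]n2)cc(OC)c1OC` gives 85%
Compound 2 `COc1cc(-c2cc(/C=C/C(=O)c3ccc(Cl)c(Cl)c3)[nH]n2)cc(OC)c1OC` gives 89%

Compound 1 holds the lowest of these two numbers, and its nearest neighbour is compound 2, reached by a number 4 percentage points higher from compound 1 to compound 2 (within the scatter), a step in which 3,4-dichlorophenyl stands in place of 4-aminophenyl on a carbonyl carbon. Compound 3 `COc1ccc(C(=O)/C=C/c2cc(-c3cc(OC)c(OC)c(OC)c3)n[nH]2)cc1` differs from compound 1 at the same ring: methoxy in place of amino on an aromatic carbon. Among the measured compounds shown here, the one measured step that bears on this is the exchange of the group on that ring between compound 1 and compound 2, and it stayed within the scatter. Nothing in the data points to a larger movement when methoxy replaces amino, so the step from compound 1 to compound 3 is expected to be no larger than the scatter. Compound 3 is therefore estimated to give 86%, within a range from 74% to 96%. That estimate means an expected step of a number 1 percentage points higher from compound 1 to compound 3 (within the scatter).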

Compound 3, a percentage reported as activity, at one concentration (the size of the read-out at that concentration, not a potency): 97%
For compound 3 the middle estimate is 11 percentage points below the measured one, and the stated range ends below it.
By their numbers in this assay, from the lowest: compounds 1, 2 and 3 (each within the scatter of the next, the first and the last beyond it).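

The position on this ring does respond to the group it carries: in this assay, the change from amino to methoxy gives a number 12 percentage points higher from compound 1 to compound 3 (beyond the scatter), whereas the earlier exchange gave only a number 4 percentage points higher from compound 1 to compound 2 (within the scatter). Compound 2 does not separate from compound 3, with a number 8 percentage points higher from compound 2 to compound 3 (within the scatter), so the 3,4-dichlorophenyl compound lies within the scatter of both others and only the two compounds with a single group at this place stand apart. No measurement shown here accounts for the step.

As far as these compounds go, with a single concentration and three compounds, it remains open whether the amino group itself matters or whether methoxy alone raises the number. A hydroxyl or a dimethylamino group at the same place could help separate these two readings.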